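Methyl in place of hydrogen on the chain of compound 1

The compounds below may be only part of what the source reports. "The series", "measured", "known", "first", "only" and "open" are said of these compounds alone.

Measured so far in an in vitro functional assay on Sf9 cells for antagonist activity at histamine H2 receptor (Homo sapiens); a lower number here means a less potent compound, a higher number a more potent compound, by a factor of ten per unit of this negative logarithm:
compound 1 `N#C/N=C(/NCCCCc1c[nH]cn1)NCCCc1ccccc1` gives 5.25
compound 2 `N#C/N=C(/NCCCCc1c[nH]cn1)NCCC(c1ccccc1)c1ccccc1` gives 5
compound 3 `N#C/N=C(/NCCCCc1c[nH]cn1)NCCCc1ccncc1` gives 5.11

Compound 1 holds the highest of the three numbers, but its nearest neighbour compound 3 and its furthest neighbour compound 2 both lie within the scatter of it, so no order among the three can be read from these values. Compound 4 `CC(CCN/C(=N\C#N)NCCCCc1c[nH]cn1)c1ccccc1` is the next step from compound 1, differing by methyl in place of hydrogen on a saturated chain carbon bound to an aromatic carbon and a saturated chain carbon.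

The step that bears most directly on this change is a number 0.25 log units lower from compound 1 to compound 2 (within the scatter), where a group enters at the same saturated chain carbon bound to an aromatic carbon and a saturated chain carbon. The step of a number 0.14 log units lower from compound 1 to compound 3 (within the scatter) concerns the aryl end of the chain and is less directly comparable. Both steps were within the scatter. A methyl at this place is therefore expected to leave the number essentially where compound 1 stands, with at most a small lowering, estimated as a number 0.10 log units lower from compound 1 to compound 4 (within the scatter). For compound 4 the estimate is 5.15, expected to fall between 4.7 and 5.6.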

Compound 4, negative logarithm of the antagonist equilibrium constant: < 5
Compound 4: only a limit was reported (the forecaster's own chance of this, stated with the estimate: 5%); middle value at least 0.15 log units from the limit.
By their numbers in this assay, from the lowest: compounds 2, 3 and 1 (each within the scatter of the next).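

Compound 4 is reported in this assay only as a limit: the limit of < 5 in this assay, at which 1 of the 4 values shown sits.

At the saturated chain carbon bound to an aromatic carbon and a saturated chain carbon, methyl gives a number at least 0.25 log units lower from compound 1 to compound 4 (that floor lies within the scatter), and the comparison with the pyridin-4-yl compound gives a number at least 0.11 log units lower from compound 3 to compound 4 (that floor lies within the scatter); methyl in place of phenyl at this carbon gives a number no higher from compound 2 to compound 4 (the limit leaves the size open). With phenyl in compound 2 and methyl in compound 4, neither group at this carbon shows a gain over the hydrogen of compound 1, though neither step is shown to lie beyond the scatter.

On these data alone, how far compound 4 truly lies from compound 1 stays open, since only a floor is available for that step. Also open, as far as these compounds go, is whether a hydroxyl group or a fluorine atom at this carbon would follow methyl and phenyl.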